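Pyrazole to Triazole on the Sulfonyl Sulfur

A few compounds are considered here, and "the series" means these few. Any claim that something is new, unique, unknown or untested is made for them only; others in the source may bear on it.

Compound 2 `Cn1cc(S(=O)(=O)N2CC(CNC(=O)c3ccc(Cl)cc3Cl)(CC3CC3)C2)cn1` gives 3.62 nM in an assay on JAR cells for inhibition of sodium- and chloride-dependent glycine transporter 1 (Homo sapiens), read by scintillation counting, with a stated time of 3 h (a higher number here means a weaker inhibitor, a lower number a stronger inhibitor), nominally the higher of the two numbers on record, though the gap to compound 1 `Cn1cc(S(=O)(=O)N2CC(CNC(=O)c3ccc(Cl)cc3Cl)(c3ncccc3F)C2)cn1` at 2.95 nM is within the scatter. For the measured compounds named here, the one measured step, a 1.2-fold higher number from compound 1 to compound 2 (0.09 log units; within the scatter), concerns a substituent on a saturated ring carbon and leaves the sulfonyl end untouched. Compound 3 `Cn1nncc1S(=O)(=O)N1CC(CNC(=O)c2ccc(Cl)cc2Cl)(CC2CC2)C1` has not yet been measured; it differs from compound 2 by 1-methyl-1H-1,2,3-triazol-5-yl in place of 1-methyl-1H-pyrazol-4-yl on a sulfonyl sulfur. Going by the values given here, no measured step bears on this change, so compounds 1 and 2 only show that the shared core holds its inhibition while a group elsewhere is exchanged. In the absence of any guiding step, a change of a 1.2-fold higher number from compound 2 to compound 3 (0.09 log units; within the scatter) is expected, that is, no movement beyond the scatter. Compound 3 is therefore estimated at 4.5 nM, with a range from 1.5 nM to 14 nM.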

Compound 3, half-maximal inhibitory concentration: 185 nM
For compound 3 the middle estimate is 41-fold (1.61 log units) below the measured one; measured number above the stated range.
By their numbers in this assay, from the lowest: compounds 1 and 2 (each within the scatter of the next); then compound 3.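

The sulfonyl sulfur proves to be a sensitive position in this assay. With everything else held fixed, 1-methyl-1H-1,2,3-triazol-5-yl in place of 1-methyl-1H-pyrazol-4-yl gives a 51-fold higher number from compound 2 to compound 3 (1.71 log units; beyond the scatter), whereas the exchange on the saturated ring carbon between compounds 1 and 2 stayed within the scatter. The shared core therefore does not hold its inhibition whatever sits on the sulfonyl sulfur, even though both groups are five-membered aromatic rings with the same number of heavy atoms, and nothing available accounts for the loss.

Going by these compounds, it remains open whether the same exchange would cost as much with 3-fluoropyridin-2-yl on the saturated ring carbon, as in compound 1. Also open, on these data alone, is how a phenyl or a 1-methylimidazolyl group on the sulfonyl sulfur would compare.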